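Replacing the chlorinated methylphenyl ring with a fluorophenyl ring

A few compounds are considered here, and "the series" means these few. Any claim that something is new, unique, unknown or untested is made for them only; others in the source may bear on it.

Three compounds in this set share one core and differ only in the ring attached to the oxygen on the aromatic ring. Compound 1 `S=C(N/N=C/c1ccc(Oc2ccccc2)cc1)Nc1ccccc1` carries a plain phenyl there and gives 4.9 in a physicochemical assay for lipophilicity, in phosphate buffer, measured as octanol-water partition, with a stated time of 24 h; a higher number here means a more lipophilic compound, a lower number a more polar compound. Compound 2 `O=[N+]([O-])c1ccc(Oc2ccc(/C=N/NC(=S)Nc3ccccc3)cc2)cc1` carries a 4-nitrophenyl and gives 4.95. Compound 3 `Cc1cc(Oc2ccc(/C=N/NC(=S)Nc3ccccc3)cc2)ccc1Cl` carries a 4-chloro-3-methylphenyl and gives 6.03, the highest of the three numbers, standing beyond the scatter above both others.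

Compound 4 `Fc1ccc(Oc2ccc(/C=N/NC(=S)Nc3ccccc3)cc2)cc1` is the next step from compound 3: 4-fluorophenyl in place of 4-chloro-3-methylphenyl on an oxygen on an aromatic ring. Going by the values given here, two measured steps bear on this. The step of a number 1.13 log units higher from compound 1 to compound 3 (beyond the scatter) and the step of a number 1.08 log units higher from compound 2 to compound 3 (beyond the scatter) both show that putting the 4-chloro-3-methylphenyl onto that oxygen went along with a large rise. Compound 4 removes that ring again and puts in a 4-fluorophenyl, which is nearer to the plain phenyl of compound 1 than to the ring of compound 3. Among the compounds with values here, no measured step shows a fluorophenyl against a phenyl directly, so the expected value leans on compound 1.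

A large drop is therefore expected, a number 0.93 log units lower from compound 3 to compound 4 (beyond the scatter), because a number 1.13 log units higher from compound 1 to compound 3 (beyond the scatter) marks the size of the rise being undone. Compound 4 is estimated at 5.1, within a range from 4.7 to 5.5.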

Compound 4, partition coefficient: 5.09
Compound 4: the middle estimate sits 0.01 log units above what was measured; the measured number falls inside the stated range.
By their numbers in this assay, from the lowest: compounds 1, 2 and 4 (each within the scatter of the next); then compound 3.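

In this assay, the swap of 4-chloro-3-methylphenyl for 4-fluorophenyl on this oxygen gives a number 0.94 log units lower from compound 3 to compound 4 (beyond the scatter) and shows that a substituent on this ring does not by itself bring the high number of compound 3. Fluoro also joins the two earlier rings as a change that cannot be told apart from its neighbours here, with a number 0.19 log units higher from compound 1 to compound 4 (within the scatter) and with a number 0.14 log units higher from compound 2 to compound 4 (within the scatter) as well, so the phenyl, 4-nitrophenyl and 4-fluorophenyl rings sit together and compound 3 alone stands apart. Nothing further is available to explain why the 4-chloro-3-methylphenyl ring stands apart.

Compound 3 carries both chlorine and methyl on its ring, so the compounds shown cannot say whether one of these groups or the pair accounts for its number, and a ring bearing only chlorine or only methyl would separate the two. As far as these compounds go, how a ring bearing an amine or a carboxylic acid would read at this position also remains open.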